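Hydroxyphenyl hydrazones versus a pyridyl analogue

This account rests on a few compounds, and the source may have more. Where it says the series, first, only, none or still open, it means among the compounds named here.

Measured compounds:
compound 1 `C/C(=N\NC(=O)c1cccc(S(=O)(=O)N2CCOCC2)c1)c1cc(F)ccc1O` — 4410 nM
compound 2 `C/C(=N\NC(=O)c1cccc(S(=O)(=O)N2CCOCC2)c1)c1cccc(N)c1O` — 2330 nM
compound 3 `O=C(N/N=C/c1ccccn1)c1cccc(S(=O)(=O)N2CCOCC2)c1` — 88100 nM

In a functional assay on PC-3 cells (Homo sapiens) for antiproliferative activity, read by MTT assay, with a stated time of 72 h (a higher number here means a weaker inhibitor, a lower number a stronger inhibitor), compound 3 gives the highest number of the three, beyond the scatter against both compound 1 and compound 2. Compound 1 and compound 2 share a hydroxyphenyl group on the carbon double-bonded to nitrogen, and the step of a 1.9-fold lower number from compound 1 to compound 2 (0.28 log units; within the scatter) shows that exchanging one such group for another leaves the number essentially unchanged. Compound 3 differs from compound 1 in more than one place, so only the two values themselves can be compared: the hydroxyphenyl compound sits far lower than the pyridyl compound.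

Compound 4 `O=C(N/N=C/c1cc(Br)cc(Br)c1O)c1cccc(S(=O)(=O)N2CCOCC2)c1` is not yet measured. The change is 3,5-dibromo-2-hydroxyphenyl in place of pyridin-2-yl on a carbon with a double bond to nitrogen. For the measured compounds named here, no single measured step covers this exchange; the only bearing comes from compound 1 and compound 2, both carrying a hydroxyphenyl group and both giving far lower numbers than compound 3. On that basis a large drop is expected for compound 4, of roughly a 22-fold lower number from compound 3 to compound 4 (1.34 log units; beyond the scatter), bringing it near compound 1 and compound 2. The estimate for compound 4 in this assay is 4000 nM, within a range of 1000 nM to 20000 nM.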

Compound 4, half-maximal inhibitory concentration: 9700 nM
Compound 4: middle estimate off by 2.4-fold (0.38 log units), on the low side; measured number inside the range.
By their numbers in this assay, from the lowest: compounds 2 and 1 (each within the scatter of the next); then compound 4; then compound 3.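

For the compounds shown here, the exchange of pyridin-2-yl for 3,5-dibromo-2-hydroxyphenyl on a carbon with a double bond to nitrogen reads in this assay as a 9.1-fold lower number from compound 3 to compound 4 (0.96 log units; beyond the scatter) and is the first step at this position with the rest of the molecule held fixed. The earlier gap between the hydroxyphenyl and pyridyl compounds came from a comparison differing in more than one place, whereas this step ties a change beyond the scatter to the exchange of this one group, in which the ring nitrogen leaves and the hydroxy group and the bromine atoms enter together. No measured property on hand accounts for the step.

Which part of the entering group carries the step stays open: a plain phenyl or a 2-hydroxyphenyl without bromine on the same carbon would separate the hydroxy group from the bromine atoms. Going by these compounds alone, also open is the methyl group on that carbon, carried by compound 1 and compound 2 and absent from compound 3 and compound 4, and no single step here isolates it.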